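A few compounds are considered here, and "the series" means these few. Any claim that something is new, unique, unknown or untested is made for them only; others in the source may bear on it.

Measured so far in a functional assay on CFPAC-1 cells (Homo sapiens) for antiproliferative activity, read by MTT assay, with a stated time of 72 h; on this read-out lower numbers stand for stronger inhibition and higher numbers for weaker inhibition:
- compound 1 `C[Si](C)(C)c1cn(C[C@H](O)[C@H]2OC(=O)C(OCc3ccccc3)=C2OCc2ccccc2)nn1`: 52600 nM
- compound 2 `O=C1O/C(=C\Cn2cc(-c3ccc(Br)cc3)nn2)C(OCc2ccccc2)=C1OCc1ccccc1`: a limit
- compound 3 `CC(C)(C)OC(=O)N1CCN(C(=S)SCc2cn(C[C@H](O)[C@H]3OC(=O)C(OCc4ccccc4)=C3OCc3ccccc3)nn2)CC1`: a limit

For the measured compounds named here, compound 1 is the only member of the series with a number in this assay, and that number, 52600 nM, stands at the weak end of what this assay resolves. For compound 2 the result is a limit of the assay, > 100000 nM, and not a number. For compound 3 the result is likewise a limit, > 100000 nM, and not a number. Going by the values given here, two of the three results therefore sit at the limit of > 100000 nM in this assay, at which 2 of the 3 values shown sit, so no step between measured compounds can be drawn, and no direction is known for any structural change.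

Compound 4 `CCCCCCCCCCc1cn(C[C@H](O)[C@H]2OC(=O)C(OCc3ccccc3)=C2OCc2ccccc2)nn1` differs from compound 1 in one place: a group of 10 heavy atoms (10 carbon; no ring) in place of a group of 4 heavy atoms (3 carbon, 1 silicon; no ring), on an aromatic carbon

Among the compounds with values here, with only one number in hand, the size of this step cannot be anchored to anything measured. The decyl group is expected to shift the read-out by roughly a 2.6-fold lower number from compound 1 to compound 4 (0.42 log units; beyond the scatter), toward stronger inhibition but by no more than a modest amount. Compound 4 is therefore estimated at 20000 nM, with a range from 5000 nM to 100000 nM, and it remains possible that this assay returns only a limit for it.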

Compound 4, half-maximal inhibitory concentration: 40300 nM
Compound 4: the middle estimate sits 2.0-fold (0.30 log units) below what was measured; measured number inside the range.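

In this assay, the decyl group on the aromatic carbon of the five-membered ring, in place of the group of 4 heavy atoms that holds the silicon, gives a 1.3-fold lower number from compound 1 to compound 4 (0.12 log units; within the scatter). For the compounds shown here, this is the first step with a number at both ends, and it shows that this position takes a swap from 4 to 10 heavy atoms, with silicon exchanged for an all-carbon chain, without a read-out difference beyond the scatter; neither group has a ring or any hydrogen-bond donor or acceptor. Compound 4 therefore joins compound 1 among the results that are numbers, while the remaining results are limits and not numbers, so no further step can be read: the limit of > 100000 nM in this assay, at which 2 of the 4 values shown sit.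

What the compounds shown leave open is whether any group at this position moves the read-out beyond the scatter, since both groups here are free of rings, donors and acceptors. A primary amine, a carboxylic acid or a phenyl ring on this same carbon, with the rest of the core of compound 1 kept, would test that directly.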